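Chloro position on the benzylsulfanyl arm and arterial inhibition

This account rests on a few compounds, and the source may have more. Where it says the series, first, only, none or still open, it means among the compounds named here.

Of the compounds shown here, three of a shared core have been measured so far, and a fourth awaits its number. Compound 1 is `CC1=C(C(=O)Nc2ccc(F)cc2)C(c2ccc([N+](=O)[O-])cc2)N=C(SCc2cccc(Cl)c2)N1`, compound 2 is `CC1=C(C(=O)Nc2ccc(F)cc2)C(c2ccc([N+](=O)[O-])cc2)N=C(SCc2ccc(Cl)cc2)N1`, and compound 3 is `CC1=C(C(=O)Nc2ccc(Br)cc2)C(c2ccc(Cl)cc2Cl)N=C(SCc2cccc(Cl)c2)N1`. In a functional assay on the whole organism (artery, strain albino) with Rattus norvegicus as the target, with a stated time of 720 min, at a dose of 10 mg/kg by the oral route (on this read-out lower numbers stand for less inhibition and higher numbers for more inhibition at the one dose given (going by the name of the read-out)), compound 1 gives 12.9%, compound 2 gives 22.2%, and compound 3 gives 11.3%. Compound 2 differs from compound 1 only in one place, (4-chlorophenyl in place of 3-chlorophenyl on a saturated chain carbon bound to a sulfur), and this change made a step of a number 9.3 percentage points higher from compound 1 to compound 2 (within the scatter). The cores of compound 1 and compound 3 differ in more than one place; that difference is not broken down here. Compound 4 is `CC1=C(C(=O)Nc2ccc(Br)cc2)C(c2ccc(Cl)cc2Cl)N=C(SCc2ccc(Cl)cc2)N1`, and it differs from compound 3 by 4-chlorophenyl in place of 3-chlorophenyl on a saturated chain carbon bound to a sulfur, the same change as that from compound 1 to compound 2, at the same place. For compound 4 in this assay a value of 18% is expected, lying between 6% and 32%. The expected step is a number 6.7 percentage points higher from compound 3 to compound 4 (within the scatter). This expectation rests on the step of a number 9.3 percentage points higher from compound 1 to compound 2 (within the scatter), with the caution that a single earlier example, itself within the scatter, is a thin base.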

Compound 4, a percentage reported as inhibition, in the whole organism at one dose (the size of the read-out at that dose, not a potency): 25.8%
The estimate for compound 4 lay 7.8 percentage points below the measured number; measured number inside the range.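

In this assay, replacing 3-chlorobenzyl with 4-chlorobenzyl on the sulfur gave a step of a number 14.5 percentage points higher from compound 3 to compound 4 (beyond the scatter) and so cleared the usual scatter on this second core. Both steps point the same way, and their sizes cannot be told apart, so the change appears to carry over from one core to the other: the same change on two cores in this assay, a number 9.3 percentage points higher (within the scatter) from compound 1 to compound 2 and a number 14.5 percentage points higher (beyond the scatter) from compound 3 to compound 4, 5.2 percentage points apart, within the scatter of two such steps. Among these compounds, this rests on only two pairs, and the earlier step alone lies within the scatter, so it shows neither a fixed size for the step nor that the step would hold on any further core.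

The two cores also differ in more than one place, which leaves open which of those differences, if any, affects the size of the step. Also open, going by these compounds, is whether an unsubstituted benzyl, a benzyl carrying methoxy in place of chlorine, or a longer chain such as phenylethyl on the sulfur would give numbers that fit the same picture.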